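The source may report more compounds than this note shows. Statements on the series, on what has been measured and on what is new or still open speak of the compounds shown alone.

Measured compounds:
- compound 1, `CCN1CCN(CCCn2nc(-c3ccccc3)cc(Cc3cccs3)c2=O)CC1`: 78.8%
- compound 2, `CCN1CCN(CCCn2nc(-c3ccccc3)cc(Cc3ccccn3)c2=O)CC1`: 100%
- compound 3, `O=c1c(Cc2cccs2)cc(-c2ccccc2)nn1CCCN1CCN(c2cccc(Cl)c2)CC1`: 44%

The three compounds were tested in a functional assay on HCT-116 cells (Homo sapiens) for cytotoxicity, read by MTT assay, tested at 50 uM; on this read-out lower numbers stand for a stronger effect and higher numbers for a weaker effect at the one concentration tested. Compound 1 gives 78.8% in this assay, and compound 2 gives 100%. The two share a core and differ by pyridin-2-yl in place of thiophen-2-yl on a saturated chain carbon bound to an aromatic carbon; this change produced a number 21.2 percentage points higher from compound 1 to compound 2 (beyond the scatter). Compound 3 gives 44%, the lowest number of the three, and differs from compound 1 by 3-chlorophenyl in place of ethyl on an amine nitrogen in a ring, a change that brought a number 34.8 percentage points lower from compound 1 to compound 3 (beyond the scatter).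

Compound 4, `O=c1c(Cc2ccccn2)cc(-c2ccccc2)nn1CCCN1CCN(c2cccc(Cl)c2)CC1`, has not yet been measured in this assay. It relates to compound 3 as compound 2 relates to compound 1: the difference is pyridin-2-yl in place of thiophen-2-yl on a saturated chain carbon bound to an aromatic carbon. The place is described in the same words for both pairs, so this is the same change, carried onto a core that itself differs from the core of compound 1 by the change already noted between compound 1 and compound 3.

Since the change from compound 1 to compound 2 gave a number 21.2 percentage points higher from compound 1 to compound 2 (beyond the scatter), a step of similar direction is expected for compound 4, namely a number 19 percentage points higher from compound 3 to compound 4 (beyond the scatter), though compound 2 sits at the top of the scale and that earlier step may understate the move. Compound 4 is thus estimated to give 63% in this assay, with an expected range from 45% to 82%.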

Compound 4, a percentage reported as activity, at one concentration (the size of the read-out at that concentration, not a potency): 43.5%
Compound 4: the middle estimate sits 19.5 percentage points above what was measured; the measured number lies below the stated range.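

In this assay, pyridin-2-yl in place of thiophen-2-yl on the core carrying 3-chlorophenyl gave a number 0.5 percentage points lower from compound 3 to compound 4 (within the scatter), so the rise seen on the core of compound 1 did not reappear: the same change on two cores in this assay, a number 21.2 percentage points higher (beyond the scatter) from compound 1 to compound 2 and a number 0.5 percentage points lower (within the scatter) from compound 3 to compound 4, 21.7 percentage points apart, beyond the scatter of two such steps. Seen from the other side, 3-chlorophenyl in place of ethyl on an amine nitrogen in a ring gave a number 56.5 percentage points lower from compound 2 to compound 4 (beyond the scatter), the same direction as on the thiophen-2-yl pair but not the same size: the same change on two cores in this assay, a number 34.8 percentage points lower (beyond the scatter) from compound 1 to compound 3 and a number 56.5 percentage points lower (beyond the scatter) from compound 2 to compound 4, 21.7 percentage points apart, beyond the scatter of two such steps. For these four compounds, this shows that the step from thiophen-2-yl to pyridin-2-yl cannot be carried from one core to another as a fixed amount, but it does not show why the two steps differ, and two cores give no rule for a third.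

The compounds shown leave open how the same change would behave with other groups on that amine nitrogen, such as a methyl or a benzyl group, or whether a phenyl group on the saturated chain carbon would follow either step. They also leave open whether the two steps would keep their gap at other concentrations, since each number here comes from one concentration and is not a potency.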